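A few compounds are considered here, and "the series" means these few. Any claim that something is new, unique, unknown or untested is made for them only; others in the source may bear on it.

Measured compounds in the series:

compound 1 `CCc1nnc(SCC(=O)c2ccc(Cl)cc2)n1N1C(=O)c2ccccc2C1=O` — in a functional assay on PC-3M cells (Homo sapiens) for cytotoxicity, read by MTT assay, with a stated time of 48 h (on this read-out lower numbers stand for stronger inhibition and higher numbers for weaker inhibition), compound 1 gives > 200000 nM, a limit of the assay and not a number.
compound 2 `CCCc1nnc(SCC(=O)c2ccc(Cl)cc2)n1N1C(=O)c2ccccc2C1=O` — in this assay compound 2 gives > 200000 nM, again a limit of the assay.
compound 3 `COc1cc(-c2nnc(SCC(=O)c3ccc(Cl)cc3)n2N2C(=O)c3ccccc3C2=O)cc(OC)c1OC` — in this assay compound 3 gives 20700 nM.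

Among the compounds with values here, compound 3 therefore holds the only number so far; the other two values sit at the limit described in the limit of > 200000 nM in this assay, at which 2 of the 3 values shown sit. The step from compound 1 to compound 2 reads a step that the two limits leave unreadable from compound 1 to compound 2. The steps that give a readable size are an at least 9.6-fold lower number from compound 1 to compound 3 (0.98 log units; beyond the scatter) and an at least 9.6-fold lower number from compound 2 to compound 3 (0.98 log units; beyond the scatter), both concerning the group on the aromatic carbon of the core, not the aryl ketone.

Compound 4 `COc1cc(-c2nnc(SCC(=O)c3ccccc3C)n2N2C(=O)c3ccccc3C2=O)cc(OC)c1OC` differs from compound 3 by 2-methylphenyl in place of 4-chlorophenyl on a carbonyl carbon. Within the data shown here, no measured step touches this part of the molecule, so the measured steps give no guidance on its direction or size. Compound 4 is estimated at 25000 nM in this assay, within 7000 nM to 90000 nM, the expected step from compound 3 to compound 4 being a 1.2-fold higher number from compound 3 to compound 4 (0.08 log units; within the scatter), i.e. none beyond the scatter, with a wide range to reflect the absence of bearing steps.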

Compound 4, half-maximal inhibitory concentration: > 200000 nM
Compound 4 was reported as a limit; the forecaster's own chance of this, stated with the estimate: 15%; middle value at least 8.0-fold (0.90 log units) away from the limit.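

The aryl ketone part is not a silent region of the series: with the 3,4,5-trimethoxyphenyl group held constant, 2-methylphenyl in place of 4-chlorophenyl on a carbonyl carbon gives an at least 9.6-fold higher number from compound 3 to compound 4 (0.98 log units; beyond the scatter) in this assay. Compound 4 gives > 200000 nM, a limit of the assay and not a number. The 3,4,5-trimethoxyphenyl group alone is therefore not enough for a readable number, since compound 4 carries it too, and compound 3 remains the only compound with a number: the limit of > 200000 nM in this assay, at which 3 of the 4 values shown sit.

The compounds shown do not separate the departure of the chlorine from the arrival of the methyl group, so how a 4-methylphenyl or a 2-chlorophenyl on this carbonyl carbon would read stays open. Also open, going by these compounds, is whether a 4-bromophenyl there would keep, raise or lower the number of compound 3.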